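Benzylamide aryl swap in an aminopyridine series

The source may report more compounds than this note shows. Statements on the series, on what has been measured and on what is new or still open speak of the compounds shown alone.

Measured so far in a functional assay on HCC78 cells (Homo sapiens) for antiproliferative activity, read by MTT assay, with a stated time of 48 h; on this read-out lower numbers stand for stronger inhibition and higher numbers for weaker inhibition:
compound 1 `Cc1ccc(CNC(=O)c2cccc(C(C)Oc3ccnc(Nc4cnn(C5CCN(C)CC5)c4)c3)c2)cc1`: 8100 nM
compound 2 `Cc1ccc(CNC(=O)c2cccc(C(C)Oc3ccnc(Nc4nc5ccccc5[nH]4)c3)c2)cc1`: > 100000 nM, a limit, not a number

In this assay, going by the values given here, compound 1 gives 8100 nM, the only number in hand. Compound 2 sits at a limit (the limit of > 100000 nM in this assay, at which 1 of the 2 values shown sits). Among the compounds with values here, the single measured step, an at least 12-fold higher number from compound 1 to compound 2 (1.09 log units; beyond the scatter), concerns the group on the amino nitrogen of the shared core, not the benzylamide end.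

Compound 3 `COc1ccc(CNC(=O)c2cccc(C(C)Oc3ccnc(Nc4cnn(C5CCN(C)CC5)c4)c3)c2)cc1OC` differs from compound 1 by 3,4-dimethoxyphenyl in place of 4-methylphenyl on a saturated chain carbon bound to an amide-type nitrogen. Within the data shown here, no measured step touches this part of the molecule, so no change beyond the scatter is expected. Compound 3 is estimated at 8000 nM, between 3000 nM and 25000 nM. The expected step is a 1.0-fold lower number from compound 1 to compound 3 (0.01 log units; within the scatter).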

Compound 3, half-maximal inhibitory concentration: 9000 nM
Compound 3: the middle estimate sits 1.1-fold (0.05 log units) below what was measured; the range from low to high includes it.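

Going by these compounds alone, compound 3 gives the first reading at the benzylamide end: in this assay, 3,4-dimethoxyphenyl in place of 4-methylphenyl on a saturated chain carbon bound to an amide-type nitrogen gives a 1.1-fold higher number from compound 1 to compound 3 (0.05 log units; within the scatter). Compound 1 and compound 3 therefore cannot be told apart here, so this aryl swap does not register on this read-out. No measured property on hand bears on this result.

Still open, as far as these compounds go, is whether an aryl group carrying a primary amine or a carboxylic acid, or a longer chain at this place, would move the value beyond the scatter.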